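A few compounds are considered here, and "the series" means these few. Any claim that something is new, unique, unknown or untested is made for them only; others in the source may bear on it.

The measured compounds in a physicochemical assay for solubility; a lower number here means a less soluble compound, a higher number a more soluble compound:
- compound 1, `CN(C)CC(=O)N1CCC(NS(=O)(=O)c2cc(S(=O)(=O)c3ccccc3)ccc2C(F)(F)F)CC1`: 100000 nM
- compound 2, `O=C(CN1CCCC1)N1CCC(NS(=O)(=O)c2cc(S(=O)(=O)c3ccccc3)ccc2C(F)(F)F)CC1`: 25000 nM
- compound 3, `CC(C)(C)C(=O)N1CCC[C@H]1C(=O)N1CCC(NS(=O)(=O)c2cc(S(=O)(=O)c3ccccc3)ccc2C(F)(F)F)CC1`: 50000 nM

Among these three, compound 1 gives the highest number in this assay. Its nearest neighbour is compound 3, a 2.0-fold lower number from compound 1 to compound 3 (0.30 log units; within the scatter), and its furthest is compound 2, a 4.0-fold lower number from compound 1 to compound 2 (0.60 log units; beyond the scatter). The step from compound 2 to compound 3 is a 2.0-fold higher number from compound 2 to compound 3 (0.30 log units; within the scatter).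

The unmeasured compound 4, `CN(C)CC(=O)N1CCC[C@H]1C(=O)N1CCC(NS(=O)(=O)c2cc(S(=O)(=O)c3ccccc3)ccc2C(F)(F)F)CC1`, differs from compound 1 in one place: 1-(((dimethylamino)methyl)carbonyl)pyrrolidin-2-yl in place of (dimethylamino)methyl on a carbonyl carbon. Among the compounds with values here, the step that bears most directly on this change is the one from compound 1 to compound 3, a 2.0-fold lower number from compound 1 to compound 3 (0.30 log units; within the scatter), in which a pyrrolidin-2-yl carrying a carbonyl on its nitrogen also replaced the (dimethylamino)methyl on the same carbonyl carbon. That step stayed within the scatter. Compound 4 keeps the (dimethylamino)methyl on its carbonyl that compound 1 has, while adding the pyrrolidin-2-yl as in compound 3, so no step beyond the scatter is expected in this assay in either direction. Compound 4 is therefore estimated at 70000 nM, with a range of 30000 nM to 160000 nM, which means an expected step of a 1.4-fold lower number from compound 1 to compound 4 (0.15 log units; within the scatter).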

Compound 4, solubility: 100000 nM
Estimate against measurement, compound 4: 1.4-fold (0.15 log units) below; the measured number falls inside the stated range.
By their numbers in this assay, from the lowest: compounds 2, 3, 1 and 4 (each within the scatter of the next, the first and the last beyond it).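

In this assay, the 1-(((dimethylamino)methyl)carbonyl)pyrrolidin-2-yl in place of (dimethylamino)methyl gives no change at the digits printed from compound 1 to compound 4 (within the scatter) at this carbonyl carbon, so a group with a five-membered non-aromatic ring and a defined stereocentre can enter here without a step beyond the scatter. The earlier step to compound 3 had tested a similar ring with a tert-butyl on its carbonyl, and exchanging that tert-butyl for (dimethylamino)methyl gives a 2.0-fold higher number from compound 3 to compound 4 (0.30 log units; within the scatter) with no step beyond the scatter either. Compound 2 now lies beyond the scatter from two compounds, with a 4.0-fold higher number from compound 2 to compound 4 (0.60 log units; beyond the scatter) joining a 4.0-fold lower number from compound 1 to compound 2 (0.60 log units; beyond the scatter) on the same scale, although compound 3 goes against any clean split, as a 2.0-fold higher number from compound 2 to compound 3 (0.30 log units; within the scatter) stays within the scatter. No measurement given here explains these numbers.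

The compounds shown leave open how a primary amine or a carboxylic acid in place of the dimethylamino would read in this assay on this ring-bearing group. They also leave open what a longer chain between the carbonyl and the dimethylamino, or the opposite configuration at the stereocentre, would do.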